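Thiophen-2-yl for furan-2-yl on the ethenyl chain

A few compounds are considered here, and "the series" means these few. Any claim that something is new, unique, unknown or untested is made for them only; others in the source may bear on it.

Among the measured compounds shown here, in a functional assay on A549 cells (Homo sapiens) for cytotoxicity (on this read-out higher numbers stand for an effect only at larger amounts of compound and lower numbers for an effect already at smaller amounts), compound 3 `COC1=C(C)C(=O)/C(=C(O)/C=C/c2ccco2)C(=O)C1(C)C` gives 10 ug/mL, the highest of the three numbers so far. Compound 1 `COC1=C(C)C(=O)/C(=C(O)/C=C/c2ccc(OC)cc2)C(=O)C1(C)C` gives 3 ug/mL and compound 2 `COC1=C(C)C(=O)/C(=C(O)/C=C/c2ccccc2C)C(=O)C1(C)C` gives 4.6 ug/mL. Compound 4 `COC1=C(C)C(=O)/C(=C(O)/C=C/c2cccs2)C(=O)C1(C)C` has thiophen-2-yl in place of furan-2-yl on a double-bonded chain carbon bound to a double-bonded chain carbon. For the measured compounds named here, no measured compound carries thiophen-2-yl, so the evidence is indirect. The steps to furan-2-yl are modest, a 3.3-fold higher number from compound 1 to compound 3 (0.52 log units; beyond the scatter) and a 2.2-fold higher number from compound 2 to compound 3 (0.34 log units; beyond the scatter), while a 1.5-fold higher number from compound 1 to compound 2 (0.19 log units; within the scatter) stays within the scatter. A small move toward a lower number, within the scatter, is expected: a 1.5-fold lower number from compound 3 to compound 4 (0.19 log units; within the scatter). For compound 4 the estimated value is 6.5 ug/mL, with an expected range of 3 ug/mL to 14 ug/mL.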

Compound 4, concentration for half-maximal effect: 4.5 ug/mL
Compound 4: the middle estimate sits 1.4-fold (0.16 log units) above what was measured; the measured number falls inside the stated range.
By their numbers in this assay, from the lowest: compounds 1, 4 and 2 (each within the scatter of the next); then compound 3.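

In this assay, exchanging the ring oxygen of furan-2-yl for the sulfur of thiophen-2-yl, with the heavy-atom count unchanged, is enough to shift the number (a 2.2-fold lower number from compound 3 to compound 4 (0.35 log units; beyond the scatter)). The high number of compound 3 therefore does not extend to this other five-membered aromatic ring, and thiophen-2-yl reads level with 2-methylphenyl (a 1.0-fold lower number from compound 2 to compound 4 (0.01 log units; within the scatter)) and 4-methoxyphenyl (a 1.5-fold higher number from compound 1 to compound 4 (0.18 log units; within the scatter)). No measurement shown accounts for the difference between the two rings.

Open, as far as these compounds go, is how an amine or a carboxylic acid on the thiophen-2-yl ring would read. Also open, from the compounds shown here alone, is whether a longer chain in place of the ethenyl would keep these numbers.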